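Working notes: amine exchange on the thiocarbonyl carbon

A few compounds are considered here, and "the series" means these few. Any claim that something is new, unique, unknown or untested is made for them only; others in the source may bear on it.

Measured in a functional assay on LM7 cells (Homo sapiens) for antiproliferative activity, read by MTT assay, with a stated time of 72 h; on this read-out lower numbers stand for stronger inhibition and higher numbers for weaker inhibition:
compound 1 `O=c1cc(CSC(=S)N2CCN(c3ccccc3)CC2)oc2cc(Cl)ccc12` gives 15900 nM
compound 2 `O=c1c(CSC(=S)N2CCOCC2)coc2cc(Cl)ccc12` gives 6200 nM
compound 3 `O=c1c(CSC(=S)N2CCOCC2)coc2ccccc12` gives 12000 nM

Compound 2 has the lowest number of the three in this assay. Its nearest neighbour is compound 3, with a 1.9-fold higher number from compound 2 to compound 3 (0.29 log units; within the scatter) for hydrogen in place of chloro on an aromatic carbon, a step that stays within the scatter. For the measured compounds named here, the furthest is compound 1, whose number is beyond the scatter from that of compound 2; no single-point step links these two.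

Compound 4 `CC(C)N(C(=S)SCc1coc2cc(Cl)ccc2c1=O)C(C)C` is not yet measured. It differs from compound 2 by diisopropylamino in place of morpholin-4-yl on a thiocarbonyl carbon. Going by the values given here, no measured step in this assay touches the amine on the thiocarbonyl carbon, and the one measured step, a 1.9-fold higher number from compound 2 to compound 3 (0.29 log units; within the scatter), concerns the aromatic substituent only. There is therefore no basis for expecting a shift beyond the scatter; the estimated step from compound 2 to compound 4 is a 1.0-fold higher number from compound 2 to compound 4 (0.02 log units; within the scatter). For compound 4 the expected value in this assay is 6500 nM, with a range of 2200 nM to 20000 nM.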

Compound 4, half-maximal inhibitory concentration: > 25000 nM
Compound 4: a limit, no number (the forecaster's own chance of this, stated with the estimate: 10%); at least 3.8-fold (0.58 log units) between middle value and limit.
By their numbers in this assay, from the lowest: compounds 2, 3 and 1 (each within the scatter of the next, the first and the last beyond it). At a limit, above all of these: compound 4.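

The amine on the thiocarbonyl carbon is a position where a single exchange reaches beyond the scatter: diisopropylamino in place of morpholin-4-yl gives an at least 4.0-fold higher number from compound 2 to compound 4 (0.60 log units; beyond the scatter). The only earlier step, on the aromatic carbon, stays within the scatter, with a 1.9-fold higher number from compound 2 to compound 3 (0.29 log units; within the scatter), so among the compounds shown only the amine exchange weakens inhibition measurably. In this assay compound 4 gives > 25000 nM, which is a limit and not a number, so the step fixes a direction and a minimum size only: the limit of > 25000 nM in this assay, at which 1 of the 4 values shown sits.

The compounds shown leave open how far the number of compound 4 actually lies from the limit. They also leave open whether the ring or its oxygen matters, a question that piperidin-1-yl or dimethylamino on the thiocarbonyl carbon would help to separate.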